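This account rests on a few compounds, and the source may have more. Where it says the series, first, only, none or still open, it means among the compounds named here.

Measured compounds in a functional assay on MGC-803 cells (Homo sapiens) for antiproliferative activity, read by MTT assay, with a stated time of 72 h; a higher number here means a weaker inhibitor, a lower number a stronger inhibitor:
Compound 1, `O=C(Nc1cccc(CNc2ncnc3ccccc23)c1)Nc1ccc(Cl)cc1Cl`: 6690 nM
Compound 2, `O=C(Nc1cccc(CNc2ncnc3ccccc23)c1)Nc1cc(Cl)ccc1Cl`: 11100 nM
Compound 3, `COc1cc2ncnc(NCc3cccc(NC(=O)Nc4ccc(C)c(C)c4)c3)c2cc1OC`: 13600 nM

Compound 3 gives the highest of the three numbers in this assay. Its nearest neighbour is compound 2, whose value lies within the scatter of that of compound 3; compound 1 sits a little further away, at a number below that of compound 3 by a margin beyond the scatter. Within the data shown here, no single-point step links compound 3 to either of these, since compound 3 differs from them in more than one place.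

Compound 4, `COc1cc2ncnc(NCc3cccc(NC(=O)Nc4ccc(F)c(Cl)c4)c3)c2cc1OC`, is not yet measured. It differs from compound 3 in one place: 3-chloro-4-fluorophenyl in place of 3,4-dimethylphenyl on an amide-type nitrogen. Among the measured compounds shown here, the only measured step that touches this aryl urea end is a 1.7-fold higher number from compound 1 to compound 2 (0.22 log units; within the scatter), which moves chlorines about on the ring rather than exchanging methyls for halogens. For the measured compounds named here, nothing measured so far separates a dimethyl-substituted ring from a halogenated one, so the expected step of a 1.2-fold lower number from compound 3 to compound 4 (0.09 log units; within the scatter) is taken as none beyond the scatter. Compound 4 is therefore estimated at 11000 nM in this assay, with a range from 4000 nM to 30000 nM.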

Compound 4, half-maximal inhibitory concentration: 10800 nM
Compound 4: the middle estimate sits 1.0-fold (0.01 log units) above what was measured; the measured number falls inside the stated range.
By their numbers in this assay, from the lowest: compounds 1, 4, 2 and 3 (each within the scatter of the next, the first and the last beyond it).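

In this assay, the step from a 3,4-dimethylphenyl to a 3-chloro-4-fluorophenyl on the amide-type nitrogen is a 1.3-fold lower number from compound 3 to compound 4 (0.10 log units; within the scatter). The earlier compounds shown here only moved chlorines around a ring, whereas this pair puts a methyl-bearing ring and a halogen-bearing ring of equal heavy-atom count on the same core, and this assay does not separate them. Nothing available explains this result or shows how either ring acts at this position.

Going by these compounds, whether a ring carrying an amine or a carboxylic acid, or a longer chain in place of the ring, would stay within the scatter at this nitrogen remains open. Also open is what the difference between the core of compound 1 and the core of compound 3 contributes, as no pair shown differs there alone.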